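The source may report more compounds than this note shows. Statements on the series, on what has been measured and on what is new or still open speak of the compounds shown alone.

Compound 1 `CC(C)C(=O)OC1CCC(CN2CCN(c3cc(=O)c4cc(C(F)(F)F)cc([N+](=O)[O-])c4s3)CC2)CC1` is the parent ester of the series. In an ADME assay on Vero cells (Chlorocebus sabaeus) for cytotoxicity, read by MTT assay, with a stated time of 48 h (on this read-out higher numbers stand for weaker inhibition and lower numbers for stronger inhibition), compound 1 reaches only a limit, > 64 ug/mL. Compound 2 `O=C(OC1CCC(CN2CCN(c3cc(=O)c4cc(C(F)(F)F)cc([N+](=O)[O-])c4s3)CC2)CC1)c1ccncc1` likewise stops at a limit in this assay, > 64 ug/mL. Compound 3 `O=C(OC1CCC(CN2CCN(c3cc(=O)c4cc(C(F)(F)F)cc([N+](=O)[O-])c4s3)CC2)CC1)c1ccco1` also gives only a limit in this assay, > 64 ug/mL. Compound 1 therefore stands together with every other measured compound at the limit of > 64 ug/mL in this assay, at which 3 of the 3 values shown sit, and the steps a step that the two limits leave unreadable from compound 1 to compound 2, a step that the two limits leave unreadable from compound 1 to compound 3 and a step that the two limits leave unreadable from compound 2 to compound 3 cannot be sized. Compound 4 `O=C(OC1CCC(CN2CCN(c3cc(=O)c4cc(C(F)(F)F)cc([N+](=O)[O-])c4s3)CC2)CC1)c1ccc(F)cc1` differs from compound 1 by 4-fluorophenyl in place of isopropyl on a carbonyl carbon. Given that the earlier swaps at that carbonyl carbon all sit at the limit of > 64 ug/mL in this assay, at which 3 of the 3 values shown sit, no step beyond the scatter is expected in this assay, a step that the limit leaves unreadable from compound 1 to compound 4. Compound 4 is accordingly estimated at 90 ug/mL, within a range of 40 ug/mL to 200 ug/mL, most probably reported once more as a limit.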

Compound 4, half-maximal inhibitory concentration: > 64 ug/mL
Compound 4: no number, only a limit; the forecaster's own chance of this, stated with the estimate: 85%; the middle value lies beyond the limit too.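

In this assay, among the compounds shown here, compound 4 gives > 64 ug/mL, again a limit, so no step from compound 1, compound 2 or compound 3 to compound 4 can be read: the limit of > 64 ug/mL in this assay, at which 4 of the 4 values shown sit. The compounds shown leave open whether the group on the carbonyl carbon affects this read-out at all.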